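A few compounds are considered here, and "the series" means these few. Any claim that something is new, unique, unknown or untested is made for them only; others in the source may bear on it.

Compound 1 is `CCN(CC)c1cc2[nH]c(C3CCCCC3)nc2cc1NC(=O)OCC(F)(F)F`. In an ADME assay on Vero cells (Chlorocebus sabaeus) for cytotoxicity, read by resazurin assay, with a stated time of 3 days (a lower number here means a stronger inhibitor, a higher number a weaker inhibitor), compound 1 gives > 100 ug/mL, which is a limit of the measurement rather than a number.
Compound 2 is `CCN(CC)c1cc2[nH]c(C3CCCCC3)nc2cc1NC(=O)c1ccc(F)cc1`. In this assay compound 2 gives > 100 ug/mL, again a limit.
Compound 3 is `CCN(CC)c1cc2[nH]c(C3CCCCC3)nc2cc1NC(=O)OCCOCCOC`. In this assay compound 3 gives > 100 ug/mL, also a limit.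

Compound 3 therefore stands where every measured compound stands: at the limit of > 100 ug/mL in this assay, at which 3 of the 3 values shown sit. None of the three compounds can be placed above or below another on these numbers.

The piece follows the change from compound 3 to compound 4, which is `CCN(CC)c1cc2[nH]c(C3CCCCC3)nc2cc1NC(=O)NCc1ccccc1`. The difference is benzylamino in place of 2-(2-methoxyethoxy)ethoxy on a carbonyl carbon. The measured steps that touch the same carbonyl carbon are a step that the two limits leave unreadable from compound 1 to compound 2, a step that the two limits leave unreadable from compound 1 to compound 3 and a step that the two limits leave unreadable from compound 2 to compound 3. All three are unreadable in size, because every value involved sits at the limit of > 100 ug/mL in this assay, at which 3 of the 3 values shown sit. Nothing in these steps points in any direction for compound 4, so no step beyond the scatter is expected in this assay; the expected step is a number no higher from compound 3 to compound 4 (the limit leaves the size open).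

Compound 4 is therefore estimated to give about 100 ug/mL in this assay, with a range from 60 ug/mL to 200 ug/mL, and it is expected most likely to come back once more as a limit rather than a number.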

Compound 4, half-maximal inhibitory concentration: > 100 ug/mL
Compound 4: only a limit was reported (the forecaster's own chance of this, stated with the estimate: 80%); the middle value sits exactly at the limit.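

In this assay compound 4 gives > 100 ug/mL, again a limit and not a number. The steps to compound 4 from compound 1, compound 2 and compound 3 therefore cannot be read, and all four compounds share one position: the limit of > 100 ug/mL in this assay, at which 4 of the 4 values shown sit. The compounds shown leave open how their cytotoxicity compares and at what concentration any of them would reach half-maximal inhibition.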